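The source may hold more compounds than are shown below. What is called first, only, known or untested is meant among the compounds shown, and "the series" means these compounds.

Measured in a functional assay on SiHa cells (Homo sapiens) for antiproliferative activity, read by CCK-8 assay, with a stated time of 72 h; on this read-out higher numbers stand for weaker inhibition and lower numbers for stronger inhibition:
- compound 1 `COc1cc(-c2ncncc2-c2ccc(SC)cc2)cc(OC)c1OC`: 560 nM
- compound 2 `COc1cc(-c2ncncc2-c2ccc(C(N)=O)cc2)cc(OC)c1OC`: > 100000 nM

Compound 2 has no number and sits at the limit of > 100000 nM in this assay, at which 1 of the 2 values shown sits.

Compound 3 `COc1cc(-c2ncncc2-c2ccc(C(=O)N(C)C)cc2)cc(OC)c1OC` carries dimethylamino in place of amino on a carbonyl carbon, with dimethylamino in place of amino on a carbonyl carbon. Going by the values given here, the one measured step that bears on it is large, an at least 170-fold higher number from compound 1 to compound 2 (2.25 log units; beyond the scatter), but that step is carbamoyl in place of methylsulfanyl on an aromatic carbon. Among the compounds with values here, no measured step covers the new change, so only a much smaller shift towards lower numbers is expected in this assay. The expected step is an at least 2.5-fold lower number from compound 2 to compound 3 (0.39 log units; beyond the scatter). For compound 3 the estimate is 40000 nM, with an expected range of 6000 nM to 100000 nM.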

Compound 3, half-maximal inhibitory concentration: 20200 nM
Compound 3: middle estimate off by 2.0-fold (0.30 log units), on the high side; the measured number falls inside the stated range.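

Compound 2 has no number, only a limit: the limit of > 100000 nM in this assay, at which 1 of the 3 values shown sits.

In this assay, dimethylamino in place of amino on a carbonyl carbon gives an at least 4.9-fold lower number from compound 2 to compound 3 (0.69 log units; beyond the scatter), so activity at this position depends on what the carbonyl carries, not only on the carbonyl itself. The dimethylcarbamoyl group still falls well short of methylsulfanyl, with a 36-fold higher number from compound 1 to compound 3 (1.56 log units; beyond the scatter).

Still open, from the compounds shown here alone, is whether the shift follows the lost amino hydrogens or the added carbons, which methylamino on the same carbonyl carbon would help separate. Also open, going by these compounds, is how diethylamino, morpholine or a carboxylic acid would read in this assay.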